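A few compounds are considered here, and "the series" means these few. Any claim that something is new, unique, unknown or untested is made for them only; others in the source may bear on it.

Compound 1 `CN(CC(=O)N1CCN(c2ccccc2)CC1)C(=O)c1ccc(S(C)(=O)=O)c([N+](=O)[O-])c1`: > 60000 nM
Compound 2 `CS(=O)(=O)c1ccc(C(=O)NCCCC(=O)N2Cc3ccccc3C2)cc1[N+](=O)[O-]`: > 60000 nM

In an assay on isolated protein for inhibition of vitamin D3 receptor (Homo sapiens), read by fluorescence polarization (a lower number here means a stronger inhibitor, a higher number a weaker inhibitor), compound 1 gives only a limit of the assay, > 60000 nM. Compound 2 likewise gives only a limit, > 60000 nM. This is the limit of > 60000 nM in this assay, at which 2 of the 2 values shown sit. So neither measured compound shows a strength that can be put into a number. Compound 3 `CN(CC(=O)N1CCN(c2ccc(C(F)(F)F)cc2)CC1)C(=O)c1ccc(S(C)(=O)=O)c([N+](=O)[O-])c1` is compound 1 with trifluoromethyl in place of hydrogen on an aromatic carbon. Among the compounds with values here, no step between measured compounds is available, and the expected change is none beyond the scatter, the estimated step being a step that the limit leaves unreadable from compound 1 to compound 3. The estimate for compound 3 is 80000 nM, within 20000 nM to 300000 nM, most likely again only a limit.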

Compound 3, half-maximal inhibitory concentration: > 60000 nM
Compound 3: no number, only a limit (the forecaster's own chance of this, stated with the estimate: 85%); the middle value lies beyond the limit too.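

Compound 1 and compound 3 both give only a limit rather than a number, so no step between them can be read: the limit of > 60000 nM in this assay, at which 3 of the 3 values shown sit.

The compounds shown leave open whether any structural change gives a measurable strength in this assay.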